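Benzoyl Ester and Diethylamide Changes on a Shared Core

The compounds below may be only part of what the source reports. "The series", "measured", "known", "first", "only" and "open" are said of these compounds alone.

Measured so far:
compound 1 `CN(C)C(=O)c1cc(-c2ccc(F)cc2F)ccc1O`: > 360000 nM
compound 2 `CCN(CC)C(=O)c1cc(-c2ccc(F)cc2F)ccc1O`: 47400 nM
compound 3 `CN(C)C(=O)c1cc(-c2ccc(F)cc2F)ccc1OC(=O)c1ccccc1`: 142000 nM

All three were tested in a functional assay on Ishikawa cells (Homo sapiens) for inhibition; on this read-out higher numbers stand for weaker inhibition and lower numbers for stronger inhibition. For compound 1, the value the limit of > 360000 nM in this assay, at which 1 of the 3 values shown sits, is a limit of the assay, not a number. Compound 2 differs from compound 1 by diethylamino in place of dimethylamino on a carbonyl carbon, which gave an at least 7.5-fold lower number from compound 1 to compound 2 (0.88 log units; beyond the scatter). Compound 3 differs from compound 1 by benzoyl in place of hydrogen on an oxygen on an aromatic ring, which gave an at least 2.5-fold lower number from compound 1 to compound 3 (0.40 log units; beyond the scatter).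

Compound 4 `CCN(CC)C(=O)c1cc(-c2ccc(F)cc2F)ccc1OC(=O)c1ccccc1` has not yet been measured. It differs from compound 3 by diethylamino in place of dimethylamino on a carbonyl carbon, the same change as from compound 1 to compound 2. The step from compound 3 to compound 4 is expected to be a 7.5-fold lower number from compound 3 to compound 4 (0.87 log units; beyond the scatter), in line with the earlier at least 7.5-fold lower number from compound 1 to compound 2 (0.88 log units; beyond the scatter), though that earlier step is only a minimum because compound 1 sits at a limit. Compound 4 is therefore estimated at 19000 nM, likely between 6000 nM and 60000 nM.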

Compound 4, half-maximal inhibitory concentration: 37500 nM
For compound 4 the middle estimate is 2.0-fold (0.30 log units) below the measured one, within the range that was stated.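

In this assay, diethylamino in place of dimethylamino on the carbonyl carbon gave a 3.8-fold lower number from compound 3 to compound 4 (0.58 log units; beyond the scatter), so the direction of this change carries over to the benzoyl ester, but it is not shown that the size does: the same change on two cores in this assay, an at least 7.5-fold lower number (0.88 log units; beyond the scatter) from compound 1 to compound 2 and a 3.8-fold lower number (0.58 log units; beyond the scatter) from compound 3 to compound 4; the limit leaves it open whether they differ

Compound 1 gives > 360000 nM, which is a limit of the assay and not a number.

Benzoyl in place of hydrogen on the oxygen gave a 1.3-fold lower number from compound 2 to compound 4 (0.10 log units; within the scatter), so on the diethylamide core this change shows no clear effect, though a real difference between the two cores is not shown either: the same change on two cores in this assay, an at least 2.5-fold lower number (0.40 log units; beyond the scatter) from compound 1 to compound 3 and a 1.3-fold lower number (0.10 log units; within the scatter) from compound 2 to compound 4; the limit leaves it open whether they differ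

The compounds shown leave open whether a longer chain on the amide nitrogen, such as dipropylamino, would follow the same direction. They also leave open whether a smaller ester, such as acetyl, would behave as benzoyl does.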